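The source may report more compounds than this note shows. Statements on the series, on what has been measured and on what is new or still open speak of the compounds shown alone.

Measured so far:
compound 1 `Cc1cc(=O)n(-c2ccccc2OC(F)(F)F)nc1C(=O)Nc1ccc(Oc2ncnc3[nH]ccc23)cc1` with 22800 nM
compound 2 `Cc1cc(=O)n(-c2ccc(Br)cc2F)nc1C(=O)Nc1ccc(Oc2ncnc3[nH]ccc23)cc1` with 3660 nM

In a functional assay on HepG2 cells (Homo sapiens) for cytotoxicity, read by MTT assay, with a stated time of 72 h (a higher number here means a weaker inhibitor, a lower number a stronger inhibitor), compound 1 gives 22800 nM and stands as the highest of the two numbers; its nearest neighbour is compound 2 with 3660 nM. Among the compounds with values here, the only measured step, a 6.2-fold lower number from compound 1 to compound 2 (0.79 log units; beyond the scatter), concerns the group on the aromatic nitrogen, so it offers no guidance on a change elsewhere in the molecule.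

Compound 3 `Cc1cc(=O)n(-c2ccccc2OC(F)(F)F)nc1C(=O)Nc1ccc(Oc2ncnc3[nH]ccc23)c(F)c1` keeps the 2-(trifluoromethoxy)phenyl of compound 1 and differs from it by fluoro in place of hydrogen on an aromatic carbon, placed ortho to a large group and meta to a large group. Within the data shown here, no measured pair speaks to this kind of change, so the expectation is a step of no size beyond the scatter, a 1.0-fold lower number from compound 1 to compound 3 (0.02 log units; within the scatter). Compound 3 is therefore estimated at 22000 nM, with a range from 9000 nM to 55000 nM.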

Compound 3, half-maximal inhibitory concentration: > 60000 nM
Compound 3 ended at the assay's limit; the forecaster's own chance of this, stated with the estimate: 15%; middle value at least 2.7-fold (0.43 log units) from the limit.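

In this assay, fluoro in place of hydrogen on an aromatic carbon, ortho to a large group and meta to a large group, gives an at least 2.6-fold higher number from compound 1 to compound 3 (0.42 log units; beyond the scatter) and so lies beyond the scatter. Within the data shown here, this is the first sign that the ring carrying this position responds to a change in this assay, as the earlier pair spoke only to the group on the aromatic nitrogen. The reading for compound 3 is a limit of the assay and not a number, so the step gives only a minimum size: the limit of > 60000 nM in this assay, at which 1 of the 3 values shown sits.

The compounds shown leave open whether a chloro or a methyl at this same place would move the number in the same direction. They also leave open whether compound 2, with its 4-bromo-2-fluorophenyl, would respond to this fluoro as compound 1 does.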